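Chloro for hydrogen on the core of a purine pair

This account rests on a few compounds, and the source may have more. Where it says the series, first, only, none or still open, it means among the compounds named here.

Measured so far:
compound 1, `Nc1nc(Cl)c2ncn(Cc3ccc(CCl)cc3)c2n1`: > 100000 nM
compound 2, `ClCc1ccc(Cn2cnc3ncnc(Cl)c32)cc1`: "not determined" (no result reported)

Among the compounds with values here, compound 1, structure `Nc1nc(Cl)c2ncn(Cc3ccc(CCl)cc3)c2n1`, is the only member with a value in a functional assay on CCRF-CEM cells (Homo sapiens) for cytotoxicity, read by sulforhodamine B assay, with a stated time of 48 h (a higher number here means a weaker inhibitor of growth, a lower number a stronger inhibitor of growth), and that value, > 100000 nM, is a limit of the assay rather than a number. Compound 2, structure `ClCc1ccc(Cn2cnc3ncnc(Cl)c32)cc1`, has no result in this assay; its entry reads "not determined" (no result reported). Within the data shown here, compound 2 therefore stands nowhere on the numbers: the single value alongside it is the limit at which compound 1 sits, (the limit of > 100000 nM in this assay, at which 1 of the 2 values shown sits).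

Compound 3, structure `ClCc1ccc(Cn2cnc3nc(Cl)nc(Cl)c32)cc1`, is the next member. It differs from compound 2 by chloro in place of hydrogen on an aromatic carbon. Among the measured compounds shown here, with no measured step anywhere, the size of the step from compound 2 to compound 3 in this assay cannot be read from the data; the expectation is for no change beyond the usual scatter, and the one value in hand points to the limit region.

Compound 3 is therefore expected to give about 80000 nM in this assay, within a range from 20000 nM to 200000 nM.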

Compound 3, concentration for total growth inhibition: 31600 nM
Beside the measured number, compound 3's estimate is 2.5-fold (0.40 log units) above it; the measured number falls inside the stated range.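

No step can be read between compound 2 and compound 3: in this assay compound 3 gives 31600 nM, while compound 2 has no value to set against it. The compounds shown leave open whether chloro in place of hydrogen on this aromatic carbon changes growth inhibition at all, and by how much.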